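Adding a methoxy to the chalcone ring of compound 1

The compounds below may be only part of what the source reports. "The series", "measured", "known", "first", "only" and "open" are said of these compounds alone.

Measured compounds:
- compound 1, `COc1ccc(C(=O)/C=C/c2cc(-c3cc(OC)c(OC)c(OC)c3)n[nH]2)cc1OC`: -30%
- compound 2, `COc1ccc(C(=O)/C=C/c2cc(-c3cc(OC)c(OC)c(OC)c3)n[nH]2)cc1`: -20%
- compound 3, `COc1cc(-c2cc(/C=C/C(=O)c3ccc(F)c(F)c3)[nH]n2)cc(OC)c1OC`: -4%

In a functional assay on MOLT-4 cells (Homo sapiens) for cytotoxicity, read by sulforhodamine B assay, with a stated time of 48 h, tested at 10 uM (a lower number here means a stronger effect, a higher number a weaker effect of the compound at the concentration tested), compound 1 gives the lowest of the three numbers, although its nearest neighbour, compound 2, sits within the scatter: the change a number 10 percentage points higher from compound 1 to compound 2 (within the scatter). Compound 3 lies further off, the change a number 26 percentage points higher from compound 1 to compound 3 (beyond the scatter), and from compound 2 the change a number 16 percentage points higher from compound 2 to compound 3 (beyond the scatter).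

Compound 4, `COc1cc(C(=O)/C=C/c2cc(-c3cc(OC)c(OC)c(OC)c3)n[nH]2)cc(OC)c1OC`, differs from compound 1 in one place: methoxy in place of hydrogen on an aromatic carbon. Among the measured compounds shown here, of the measured steps, only the step from compound 1 to compound 2 bears on it directly, since that step removes a methoxy on the same ring while this one adds one, and it stayed within the scatter. The two steps leading to compound 3 change a different part of the molecule and say little here. Compound 4 is therefore expected to show no step beyond the scatter in this assay, the estimated change being a number 3 percentage points lower from compound 1 to compound 4 (within the scatter). The estimate for compound 4 is -33%, within a range from -55% to -12%.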

Compound 4, a percentage reported as activity, at one concentration (the size of the read-out at that concentration, not a potency): -4%
Compound 4: the middle estimate sits 29 percentage points below what was measured; measured number above the stated range.
By their numbers in this assay, from the lowest: compounds 1 and 2 (each within the scatter of the next); then compounds 3 and 4 (each within the scatter of the next).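

In this assay, adding the methoxy ortho to a methoxy group and meta to a large group gives a number 26 percentage points higher from compound 1 to compound 4 (beyond the scatter) and so moves the read-out beyond the scatter. Among the compounds shown here, the only earlier methoxy change on this ring, its removal, gave a number 10 percentage points higher from compound 1 to compound 2 (within the scatter) and stayed within the scatter. Methoxy changes on this ring therefore do not all behave alike, and adding one at this position is not simply the reverse of removing one. Nothing available explains this step.

Going by these compounds, whether the step belongs to methoxy itself or would also appear with a hydroxyl, an amine or a longer ethoxy chain at this position remains open. On these data alone, it is also open whether a group smaller than methoxy, such as fluorine, would leave the read-out of compound 1 within the scatter.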